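Bromo for Trifluoromethyl: Expected Change in Cell Growth Inhibition

The source may hold more compounds than are shown below. What is called first, only, known or untested is meant among the compounds shown, and "the series" means these compounds.

Compound 1, `COc1ccc2cc(C(C)c3nnc4n3N=C(c3ccc(C(F)(F)F)cc3)CS4)ccc2c1`: 10800 nM
Compound 2, `CC(c1ccc(-c2ccccc2)c(F)c1)c1nnc2n1N=C(c1ccc(C(F)(F)F)cc1)CS2`: 6100 nM
Compound 3, `CC(C)Cc1ccc(C(C)c2nnc3n2N=C(c2ccc(F)cc2)CS3)cc1`: 12400 nM

Three compounds with a shared core were tested in a functional assay on HCT-116 cells (Homo sapiens) for inhibition, read by sulforhodamine B assay, with a stated time of 72 h; on this read-out higher numbers stand for weaker inhibition and lower numbers for stronger inhibition. Compound 2 shows the lowest of the three numbers with 6100 nM; its gap to compound 1 lies within the usual scatter, while compound 3 stands beyond it. Compound 4, `CC(c1ccc(-c2ccccc2)c(F)c1)c1nnc2n1N=C(c1ccc(Br)cc1)CS2`, has not yet been measured. It differs from compound 2 in one place: bromo in place of trifluoromethyl on an aromatic carbon. For the measured compounds named here, no measured pair shows this change, so nothing is known about its effect here. The step from compound 2 to compound 4 is expected to be small, a 1.1-fold higher number from compound 2 to compound 4 (0.06 log units; within the scatter), with no clear direction beyond the scatter. Compound 4 is therefore estimated at 7000 nM, expected to fall between 3000 nM and 16000 nM.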

Compound 4, half-maximal inhibitory concentration: 7100 nM
Estimate against measurement, compound 4: 1.0-fold (0.01 log units) below; the range from low to high includes it.
By their numbers in this assay, from the lowest: compounds 2, 4, 1 and 3 (each within the scatter of the next, the first and the last beyond it).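

Going from 4-(trifluoromethyl)phenyl to 4-bromophenyl gives the first direct comparison at this position, and in this assay it shows a 1.2-fold higher number from compound 2 to compound 4 (0.07 log units; within the scatter). With the rest of the molecule unchanged, bromo and trifluoromethyl cannot be told apart at this position on this read-out. Nothing shown here offers an explanation for this.

From the compounds shown here alone, whether an amine, a carboxylic acid or a longer chain at this position would shift the number beyond the scatter remains open. Also open, going by these compounds, is whether the same change would give so small a step in compound 1.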